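The source may report more compounds than this note shows. Statements on the series, on what has been measured and on what is new or still open speak of the compounds shown alone.

Of the compounds shown here, two that share one core have so far been tested in a functional assay on the whole organism (strain Sprague-Dawley) for inhibition, with Rattus norvegicus as the target (a higher number here means that more compound is needed for the effect, a lower number that less compound is needed), and a third awaits its turn. Compound 1, with the structure `COc1ccc2ncc(-c3nn[nH]n3)cc2c1`, gives 10 mg/kg in this assay. Compound 2, with the structure `FC(F)(F)c1cccc2cc(-c3nn[nH]n3)cnc12`, gives < 25 mg/kg in this assay. For compound 2 this is a limit of the assay and not a number, so compound 2 stands only within a range on the scale shown. The evidence on that point is the limit of < 25 mg/kg in this assay, at which 1 of the 2 values shown sits.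

The unmeasured compound 3 has the structure `c1ccc2ncc(-c3nn[nH]n3)cc2c1`. It differs from compound 2 in one place: hydrogen in place of trifluoromethyl on an aromatic carbon. For the measured compounds named here, no step between two measured compounds is available here, so nothing measured tells how large such a change can be in this assay. On the numbers of compound 1 and compound 2 alone, a step of no more than the usual scatter in either direction is expected.

Compound 3 is therefore expected to give about 10 mg/kg in this assay, with a range from 3 mg/kg to 30 mg/kg. The expected step that the limit leaves unreadable from compound 2 to compound 3 is estimated to stay within the scatter.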

Compound 3, minimum effective dose: 10 mg/kg
Compound 3: the middle estimate sits on the measured number at the digits printed; low and high end bracket the measured number.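

In this assay, hydrogen in place of methoxy on an aromatic carbon gives no change at the digits printed from compound 1 to compound 3 (within the scatter). For the compounds shown here, this is the first step between two measured compounds, and it shows that the shared core carrying only hydrogen at this place keeps the effect in the same dose range, so in this pair the methoxy group is not required for activity in the whole animal. For the other change, compound 2 gives a limit of the assay and not a number, so the step for hydrogen in place of trifluoromethyl cannot be read, and whether trifluoromethyl matters stays undecided: the limit of < 25 mg/kg in this assay, at which 1 of the 3 values shown sits.

One step within the scatter is a single observation and no rule, so it cannot say whether changes on this ring generally leave the required dose alone. Also open, from the compounds shown here alone, is whether a group of another kind on the shared core, such as an amine, a carboxylic acid or a longer chain like butoxy, would move the dose beyond the scatter in this assay.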